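The source may report more compounds than this note shows. Statements on the series, on what has been measured and on what is new or still open speak of the compounds shown alone.

In a functional assay on SK-OV-3 cells (Homo sapiens) for antiproliferative activity, read by MTT assay, with a stated time of 72 h (on this read-out lower numbers stand for stronger inhibition and higher numbers for weaker inhibition), compound 1 `CCNC(=O)CCc1cccc2c1B(O)OC2`, with ethyl on its amide-type nitrogen, gives > 100000 nM, which is a limit of the assay. Compound 2 `O=C(CCc1cccc2c1B(O)OC2)Nc1ccc(Cl)cc1` gives 5000 nM. Among the compounds with values here, compound 3 `O=C(CCc1cccc2c1B(O)OC2)Nc1cccc(Br)c1` gives 540 nM, the lowest number so far. Compound 4 `CC(C)c1cccc(NC(=O)CCc2cccc3c2B(O)OC3)c1` has isopropyl in place of bromo on an aromatic carbon, meta to a large group (isopropyl in place of bromo on an aromatic carbon). Within the data shown here, no measured step makes this exact swap. The nearest is the modest 9.3-fold lower number from compound 2 to compound 3 (0.97 log units; beyond the scatter), where the group on the aromatic ring also changes. The large at least 20-fold lower number from compound 1 to compound 2 (1.30 log units; beyond the scatter) and an at least 180-fold lower number from compound 1 to compound 3 (2.26 log units; beyond the scatter) concern replacing ethyl, so they bear on it less. In this assay, the expected change is small and within the scatter, a 1.7-fold higher number from compound 3 to compound 4 (0.22 log units; within the scatter). For compound 4 the estimated value is 900 nM, with an expected range of 250 nM to 3500 nM.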

Compound 4, half-maximal inhibitory concentration: 510 nM
Compound 4: the middle estimate sits 1.8-fold (0.25 log units) above what was measured; the range from low to high includes it.
By their numbers in this assay, from the lowest: compounds 4 and 3 (each within the scatter of the next); then compound 2. At a limit, above all of these: compound 1.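

In this assay, compound 3 and compound 4 match within the scatter: a 1.1-fold lower number from compound 3 to compound 4 (0.02 log units; within the scatter). The earlier compounds shown here carried only halogens on the aromatic ring, whereas this result shows that, at this place, an isopropyl group of 3 carbon atoms can stand in for a single bromine atom with no measurable loss. Nothing measured here bears on why the two groups match.

Still open, as far as these compounds go, is whether an amine or a carboxylic acid at this same place would give a similar number. From the compounds shown here alone, a longer chain there is equally open.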